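The source may hold more compounds than are shown below. What is called first, only, known or untested is meant among the compounds shown, and "the series" means these compounds.

Of the compounds shown here, three built on a shared core have been measured in a functional assay on T47D cells (Homo sapiens) for antiproliferative activity, read by MTT assay, with a stated time of 72 h; a higher number here means a weaker inhibitor, a lower number a stronger inhibitor. With propyl on the aromatic nitrogen, compound 1 `CCCn1ccnc1-c1cc(OC)c(OC)c(OC)c1` gives > 100000 nM, which is a limit of the assay and not a number. With benzyl there, compound 2 `COc1cc(-c2nccn2Cc2ccccc2)cc(OC)c1OC` gives > 100000 nM, again a limit only. For the measured compounds named here, with 4-methylphenyl on that nitrogen, compound 3 `COc1cc(-c2nccn2-c2ccc(C)cc2)cc(OC)c1OC` gives 20500 nM, the only actual number among the three.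

The measured steps show an at least 4.8-fold lower number from compound 1 to compound 3 (0.68 log units; beyond the scatter) and an at least 4.8-fold lower number from compound 2 to compound 3 (0.68 log units; beyond the scatter), both beyond the scatter and both bounded on one side by a limit. The third comparison is a step that the two limits leave unreadable from compound 1 to compound 2.

Compound 4 `COc1cc(-c2nccn2-c2ccc(F)cc2)cc(OC)c1OC` keeps the aryl group of compound 3 but alters its substituent: fluoro in place of methyl on an aromatic carbon. This is fluoro in place of methyl on an aromatic carbon, para to a large group, so 4-methylphenyl becomes 4-fluorophenyl. Going by the values given here, none of the measured steps changes this position. They replace the whole group on the nitrogen, so they bear on it only indirectly and give no size for so small an exchange.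

With compound 3 at 20500 nM as the anchor, no shift beyond the scatter is expected in this assay, and the expected step is a 1.0-fold lower number from compound 3 to compound 4 (0.01 log units; within the scatter). For compound 4 the estimated value is 20000 nM, with an expected range from 6000 nM to 70000 nM.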

Compound 4, half-maximal inhibitory concentration: > 100000 nM
Compound 4 gave a limit, no number; the forecaster's own chance of this, stated with the estimate: 20%; at least 5.0-fold (0.69 log units) between middle value and limit.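

In this assay, the exchange of methyl for fluoro on an aromatic carbon, para to a large group, gives an at least 4.8-fold higher number from compound 3 to compound 4 (0.68 log units; beyond the scatter), so this position responds to a change of a single atom, which the replacements of the whole group on the nitrogen could not show. Compound 4 gives > 100000 nM, which is a limit and not a number, so the step has a lower bound but no measured size. Within this pair the measurable number goes with 4-methylphenyl and does not carry over to 4-fluorophenyl, while the steps to compound 4 from compound 1 and from compound 2 cannot be read, and these three compounds cannot be ordered among themselves: the limit of > 100000 nM in this assay, at which 3 of the 4 values shown sit.

As far as these compounds go, whether another group at this position, such as chloro, methoxy or an amine, would restore a measurable number stays open. From the compounds shown here alone, it also stays open whether a longer chain in place of the methyl would give a lower number than compound 3 or a limit like that of compound 4.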